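Chloro Replacing Hydroxy: Expected Cytotoxicity of Compound 3

The compounds below may be only part of what the source reports. "The series", "measured", "known", "first", "only" and "open" are said of these compounds alone.

Of the compounds shown here, two sharing one core have been tested in a functional assay on HFF cells (Homo sapiens) for cytotoxicity; on this read-out higher numbers stand for weaker inhibition and lower numbers for stronger inhibition. Compound 1 `CS(=O)(=O)c1nc(N)c2ccn(COCCO)c2n1` carries a methylsulfonyl group, and compound 2 `Nc1nc(O)nc2c1ccn2COCCO` carries hydroxy in its place. In this assay compound 1 reaches only the limit of the assay, > 100000 nM. In this assay compound 2 likewise gives only a limit, > 100000 nM. The step that the two limits leave unreadable from compound 1 to compound 2 cannot be read in size because of the limit of > 100000 nM in this assay, at which 2 of the 2 values shown sit. Compound 2 thus stands at the assay limit, not at a measured number. Compound 3 `Nc1nc(Cl)nc2c1ccn2COCCO` differs from compound 2 by chloro in place of hydroxy on an aromatic carbon between two ring nitrogen atoms. Within the data shown here, no measured step bears on this change; the one step in hand is itself unreadable. Compound 3 is therefore expected to stay at the limit, with the step that the limit leaves unreadable from compound 2 to compound 3 estimated as none beyond the scatter. The estimate for compound 3 in this assay is 150000 nM, ranging from 60000 nM to 400000 nM.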

Compound 3, half-maximal inhibitory concentration: > 100000 nM
Compound 3 gave a limit, no number; the forecaster's own chance of this, stated with the estimate: 85%; the middle value is on the limit's open side.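

In this assay, among these compounds, compound 3 also gives only a limit, so no step from compound 1 or compound 2 to compound 3 can be read: the limit of > 100000 nM in this assay, at which 3 of the 3 values shown sit. The compounds shown leave open whether methylsulfonyl, hydroxy or chloro on the shared core makes any difference to cytotoxicity.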